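Furan on the Indazole Nitrogen: An Expected Inactive Step

The source may hold more compounds than are shown below. What is called first, only, known or untested is meant among the compounds shown, and "the series" means these compounds.

Compound 2 `CCOC(=O)c1ccc(-c2nn(Cc3ccccn3)c3ccccc23)cc1`: > 10000 nM
Compound 1 `CCOC(=O)c1ccc(-c2nn(Cc3ccccc3OC)c3ccccc23)cc1`: > 10000 nM

Of the compounds shown here, two have been measured in a functional assay on cells (Platelet, Homo sapiens) for inhibition; on this read-out lower numbers stand for stronger inhibition and higher numbers for weaker inhibition. Compound 2 `CCOC(=O)c1ccc(-c2nn(Cc3ccccn3)c3ccccc23)cc1` reaches only the limit of this assay, at > 10000 nM, so no number is known for it. Compound 1 `CCOC(=O)c1ccc(-c2nn(Cc3ccccc3OC)c3ccccc23)cc1` likewise sits at the limit of this assay with > 10000 nM. Within the data shown here, the single step between them, a step that the two limits leave unreadable from compound 1 to compound 2, therefore cannot be read in size or direction; the limit of > 10000 nM in this assay, at which 2 of the 2 values shown sit, is all the two values show.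

Compound 3 `CCOC(=O)c1ccc(-c2nn(-c3ccco3)c3ccccc23)cc1` has not yet been measured. It differs from compound 2 by furan-2-yl in place of (pyridin-2-yl)methyl on an aromatic nitrogen. Among the measured compounds shown here, no measured step bears on this change, and both measured compounds sit at the limit, so there is no anchor for a readable step. The expectation is that compound 3 will also sit at or near the limit, with a step that the limit leaves unreadable from compound 2 to compound 3 that is not readable. Compound 3 is estimated at 15000 nM in this assay, within 3000 nM to 60000 nM.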

Compound 3, half-maximal inhibitory concentration: > 10000 nM
Compound 3: only a limit was reported; the forecaster's own chance of this, stated with the estimate: 80%; the middle value does not contradict the limit.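

Compound 3 gives > 10000 nM as a limit of this assay and not as a number, so its steps from compound 1 and from compound 2 cannot be read. The compounds shown leave open whether any group on the aromatic nitrogen gives measurable inhibition.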